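Phenyl to 4-methoxyphenyl in the thiocarbonyl series

A few compounds are considered here, and "the series" means these few. Any claim that something is new, unique, unknown or untested is made for them only; others in the source may bear on it.

In a functional assay on NCI-H460 cells (Homo sapiens) for cytotoxicity, read by sulforhodamine B assay (on this read-out lower numbers stand for stronger inhibition of growth and higher numbers for weaker inhibition of growth), compound 1 (`CC1=CC[C@@H]([C@@](C)(O)CCCC(C)(C)NC=S)CC1`) gives 9250 nM and compound 2 (`CC1=CC[C@@H]([C@@](C)(O)CCCC(C)(C)NC(=S)N/N=C\c2ccccc2)CC1`) gives 38400 nM as the higher of the two numbers, which places it on the weaker side of this short series. Compound 3 (`COc1ccc(/C=N\NC(=S)NC(C)(C)CCC[C@](C)(O)[C@@H]2CC=C(C)CC2)cc1`) differs from compound 2 by one change (methoxy in place of hydrogen on an aromatic carbon): methoxy in place of hydrogen on an aromatic carbon, para to a large group. Among the compounds with values here, the only measured step (a 4.2-fold higher number from compound 1 to compound 2 (0.62 log units; beyond the scatter)) was modest and lay on a thiocarbonyl carbon, not on the aromatic ring. Within the data shown here, no measured step alters a substituent on that ring, so the data give no direction here. Taking compound 2 at 38400 nM as the anchor, no shift beyond the scatter is expected in this assay and the estimated step is small (a 1.2-fold lower number from compound 2 to compound 3 (0.07 log units; within the scatter)). Compound 3 is expected at 33000 nM with an estimated range from 15000 nM to 70000 nM on this read-out.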

Compound 3, concentration for 50% growth inhibition: 5100 nM
Compound 3: the middle estimate sits 6.5-fold (0.81 log units) above what was measured, outside the stated range (below it).
By their numbers in this assay, from the lowest: compounds 3 and 1 (each within the scatter of the next); then compound 2.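

In this assay, within the data shown here, the first change on the aromatic ring gives a 7.5-fold lower number from compound 2 to compound 3 (0.88 log units; beyond the scatter), a step beyond the scatter. Methoxy in place of hydrogen, para to a large group, thus moves the number towards stronger inhibition of growth, showing that this ring position responds to substitution, which the earlier step on the thiocarbonyl carbon, a 4.2-fold higher number from compound 1 to compound 2 (0.62 log units; beyond the scatter), could not show. No evidence is at hand that bears on what lies behind this shift.

Going by these compounds, whether the shift belongs to methoxy itself or would follow from other groups at this place stays open, and a hydroxyl group, a chlorine atom or a dimethylamino group on the same carbon would help to separate these readings. Also open, on these data alone, is how methoxy would read on another aromatic carbon of the ring.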